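Same Atoms, Joined Differently: Compound 1 to Compound 3

The source may hold more compounds than are shown below. What is called first, only, known or untested is meant among the compounds shown, and "the series" means these compounds.

Compound 1 `Cc1ccc(S(=O)(=O)N2CCC(N3CCC(C)CC3)CC2)cc1C` carries a 3,4-dimethylphenyl group on the sulfonyl sulfur. In a functional assay on DLD-1 cells (Homo sapiens) for antiproliferative activity, read by CellTiter-Glo, with a stated time of 72 h (on this read-out higher numbers stand for weaker inhibition and lower numbers for stronger inhibition), compound 1 gives 24 nM, the higher of the two numbers recorded here. The lower number belongs to compound 2 `Cc1cc(S(=O)(=O)N2CCC(N3CCC(C)CC3)CC2)c(Cl)cc1Cl`, which in this assay gives 2 nM, a gap that lies beyond the scatter. Compound 3 `CCc1ccc(S(=O)(=O)N2CCC(N3CCC(C)CC3)CC2)cc1` is built from the same atoms as compound 1, joined differently: 4-ethylphenyl in place of 3,4-dimethylphenyl on a sulfonyl sulfur. Going by the values given here, no measured pair shows what such a rearrangement does, so only a modest step is expected, most likely none beyond the scatter or a slight weakening. For compound 3 the estimate in this assay is 40 nM, within a range of 12 nM to 130 nM, which corresponds to an expected step of a 1.7-fold higher number from compound 1 to compound 3 (0.22 log units; within the scatter).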

Compound 3, half-maximal inhibitory concentration: > 5000 nM
Compound 3: only a limit was reported (the forecaster's own chance of this, stated with the estimate: 2%); middle value at least 120-fold (2.09 log units) from the limit.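

Rearranging the same carbons from 3,4-dimethylphenyl to 4-ethylphenyl on a sulfonyl sulfur gives in this assay an at least 200-fold higher number from compound 1 to compound 3 (2.31 log units; beyond the scatter), so the activity at this position depends sharply on how these atoms are joined, which compound 1 and compound 2 alone did not show. The value of compound 3 is a limit of the assay and not a number: the limit of > 5000 nM in this assay, at which 1 of the 3 values shown sits.

The compounds shown leave open whether a 4-methylphenyl or a 4-propylphenyl group on the same sulfur would keep the activity of compound 1 or lose it as compound 3 does.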